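This account rests on a few compounds, and the source may have more. Where it says the series, first, only, none or still open, it means among the compounds named here.

Measured so far:
Compound 1 `c1ccc(CNc2ccc(C3CCCCC3)cc2)cc1` — in a functional assay on Jurkat cells (Homo sapiens) for activation, with a stated time of 24 h (on this read-out lower numbers stand for an effect already at smaller amounts and higher numbers for an effect only at larger amounts of compound), compound 1 is reported as "not active" (no number reported).
Compound 2 `CN1CCN(c2ccc(NCc3ccccc3O)cc2)CC1` — in this assay compound 2 is reported as "not active" (no number reported).
Compound 3 `Oc1ccccc1CNc1ccc(-c2ccc(F)cc2)cc1` — in this assay compound 3 gives 3860 nM.

For the measured compounds named here, compound 3 stands alone as the only entry with a number; compound 1 and compound 2 carry no value beyond the statement that no activity was seen, so no step between two measured compounds can be computed, and nothing is known about the size of any change.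

Compound 4 `Oc1ccccc1CNc1ccc(C2CCCCC2)cc1` differs from compound 3 in one place: cyclohexyl in place of 4-fluorophenyl on an aromatic carbon. Compound 1 also carries a cyclohexyl group and shows no activity, but it lacks the hydroxyl on the benzyl part that compound 3 and compound 4 share, so it gives only a loose hint. Going by the values given here, with no measured step to lean on, the expectation for the change from compound 3 to compound 4 is a modest loss, a 1.8-fold higher number from compound 3 to compound 4 (0.26 log units; within the scatter), with a real chance that only a limit is reported. Compound 4 is therefore estimated at 7000 nM, within 2500 nM to 25000 nM.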

Compound 4, half-maximal effective concentration: 8800 nM
Beside the measured number, compound 4's estimate is 1.3-fold (0.10 log units) below it; measured number inside the range.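

In this assay, for the compounds shown here, cyclohexyl in place of 4-fluorophenyl gives a 2.3-fold higher number from compound 3 to compound 4 (0.36 log units; beyond the scatter), the first step that can be read. The change is modest but beyond the scatter, and a number remains, so an aromatic ring at this position is not needed for a reported value in this pair. With cyclohexyl held constant, compound 1 is reported as "not active" (no number reported) while compound 4 gives 8800 nM, so within this one pair the hydroxyl on the benzyl part separates a number from no number.

Nothing at hand bears on the cause of the step. Going by these compounds, it remains open whether plain phenyl, an amine, a carboxylic acid or a longer chain at this position would keep a number, and how far the fluorine contributes to the step.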